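A few compounds are considered here, and "the series" means these few. Any claim that something is new, unique, unknown or untested is made for them only; others in the source may bear on it.

Working notes, solubility series. Within the data shown here, in a physicochemical assay for solubility, read by spectrophotometry, using the shake flask method, with a stated time of 48 h, at pH 6.5 (a lower number here means a less soluble compound, a higher number a more soluble compound), compound 2 `O=C(O)CCCOc1ccc2nc(-c3cn(-c4ccc(O)c(F)c4)nn3)ccc2c1` gives 19.2 ug/mL, the highest of the three numbers so far; compound 3 `NCCOc1ccc2nc(-c3cn(-c4ccc(O)cc4)nn3)ccc2c1` gives 3.7 ug/mL and compound 1 `Oc1ccc(-n2cc(-c3ccc4ccccc4n3)nn2)cc1` gives 2.2 ug/mL, both gaps beyond the scatter. Compound 4 `NCCOCCOc1ccc2nc(-c3cn(-c4ccc(O)c(F)c4)nn3)ccc2c1` has not been measured. It differs from compound 2 by 2-aminoethoxy in place of carboxymethyl on a saturated chain carbon, two bonds along the chain from an oxygen on an aromatic ring. Among the measured compounds shown here, the only measured step that touches this change is a 1.7-fold higher number from compound 1 to compound 3 (0.23 log units; within the scatter), where the same 2-aminoethoxy enters for hydrogen. For the measured compounds named here, no measured pair trades carboxymethyl for 2-aminoethoxy, so the number for compound 4 is expected to move by a 1.6-fold lower number from compound 2 to compound 4 (0.20 log units; within the scatter), a step within the scatter. Compound 4 is estimated at 12 ug/mL, with a range from 4 ug/mL to 35 ug/mL.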

Compound 4, solubility: 9.1 ug/mL
Estimate against measurement, compound 4: 1.3-fold (0.12 log units) above; measured number inside the range.
By their numbers in this assay, from the lowest: compounds 1 and 3 (each within the scatter of the next); then compound 4; then compound 2.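

In this assay, carboxymethyl gives way to 2-aminoethoxy on a saturated chain carbon, with a modest step (a 2.1-fold lower number from compound 2 to compound 4 (0.32 log units; beyond the scatter)). Among these compounds, the earlier compounds showed 2-aminoethoxy only entering for hydrogen on an aromatic carbon, a step within the scatter; this is the first direct exchange of the two groups, and it lies beyond the scatter. Nothing available accounts for this step.

Open, going by these compounds, is how an amide or a hydroxyl at this place would stand against compound 2 and compound 4. Also open, on these data alone, is how a longer chain ending in the same amine would compare with compound 4.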